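The source may report more compounds than this note shows. Statements on the series, on what has been measured and on what is new or still open speak of the compounds shown alone.

Working notes on the triazene series. Of the compounds shown here, three have numbers so far. Compound 1 `CN(C)/N=N/c1ccc(CCCC(=O)NN)cc1` gives 3.6 in a functional assay on L1210 cells (Mus musculus) for antiproliferative activity; on this read-out lower numbers stand for lower potency and higher numbers for higher potency (the scale is a negative logarithm). Compound 2 `Cc1ccc(/N=N/N(C)C)cc1` gives 3.76 in this assay, the highest of the three numbers, though its gap to compound 1 is within the scatter. Compound 3 `CC(=O)N(C)/N=N/c1ccc(C)cc1` gives 2.78 in this assay, the lowest of the three.

The two measured steps: a number 0.16 log units higher from compound 1 to compound 2 (within the scatter), and a number 0.98 log units lower from compound 2 to compound 3 (beyond the scatter).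

The next compound is compound 4 `CN(C)/N=N/c1ccc(NC(N)=O)cc1`, not yet measured in this assay. Compared with compound 2 the change is ureido in place of methyl on an aromatic carbon.

Going by the values given here, of the two steps, the one from compound 1 to compound 2 bears directly, as it also swaps the group on the aromatic carbon para to the dimethyltriazenyl group; that swap, from a chain of several heavy atoms to hydrogen, moved the number only within the scatter. The step from compound 2 to compound 3 changed the nitrogen substituent instead and is less relevant. A step of no more than scatter size is therefore expected in this assay for the ureido change, in either direction.

Compound 4 is expected to give about 3.7 in this assay, with a likely range from 3.1 to 4.3. This estimate implies a step of a number 0.06 log units lower from compound 2 to compound 4 (within the scatter), expected to remain within the scatter.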

Compound 4, logarithm of the reciprocal of the active concentration, log(1/C): 3.97
For compound 4 the middle estimate is 0.27 log units below the measured one; low and high end bracket the measured number.
By their numbers in this assay, from the lowest: compound 3; then compounds 1, 2 and 4 (each within the scatter of the next, the first and the last beyond it).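

In this assay, ureido in place of methyl on an aromatic carbon, para to a group of 5 heavy atoms, gives a number 0.21 log units higher from compound 2 to compound 4 (within the scatter), so this position accepts a group of 4 heavy atoms with 2 hydrogen-bond donors and 1 hydrogen-bond acceptor without a step beyond the scatter. The earlier compounds shown here carried only a saturated chain carbon at this position, whereas compound 4 shows the same outcome with a nitrogen bound directly to the aromatic carbon, so the tolerance seen with the chain of compound 1 is not limited to carbon-linked groups. Nothing available explains why the number stays within the scatter for this change.

Still open, going by these compounds, is whether the same holds for other groups bound directly at this aromatic carbon, such as an amine, a carboxylic acid or a longer chain ending in ureido. Also open, on these data alone, is whether ureido at this position would behave the same way with acetyl on the amine nitrogen, the change that separates compound 3 from compound 2.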